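The source may report more compounds than this note shows. Statements on the series, on what has been measured and on what is new or still open speak of the compounds shown alone.

Among the compounds with values here, compound 1 `CCCCCOc1ccc2nncn2n1` is the only compound of the measured pair with a number in a functional assay on the whole organism with Mus musculus as the target; on this read-out higher numbers stand for an effect only at larger amounts of compound and lower numbers for an effect already at smaller amounts: compound 1 gives 39.4 mg/kg. Compound 2 `CCCCCCCCOc1ccc2nncn2n1` reaches only a limit of this assay: compound 2 gives > 100 mg/kg. The step of an at least 2.5-fold higher number from compound 1 to compound 2 (0.40 log units; beyond the scatter) is therefore a lower bound on the shift. Compound 3 `CCCCCCCCCOc1ccc2nncn2n1` differs from compound 1 by butyl in place of hydrogen on a saturated chain carbon, five bonds along the chain from an oxygen on an aromatic ring. Within the data shown here, this change extends the same chain beyond the change that separates compound 1 from compound 2, so the measured step of an at least 2.5-fold higher number from compound 1 to compound 2 (0.40 log units; beyond the scatter) is the only step that bears on it; it pointed toward a higher number, with the limit of > 100 mg/kg in this assay, at which 1 of the 2 values shown sits, leaving its full size open. In this assay the step from compound 1 to compound 3 is expected to run in the same direction and to be of similar or larger size, a 4.1-fold higher number from compound 1 to compound 3 (0.61 log units; beyond the scatter). Compound 3 is therefore estimated at 160 mg/kg, with a range from 60 mg/kg to 450 mg/kg, and is expected more likely than not to be reported again as a limit rather than as a number.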

Compound 3, dose for half-maximal effect: > 100 mg/kg
Compound 3 gave a limit, no number; the forecaster's own chance of this, stated with the estimate: 70%; the middle value is on the limit's open side.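

In this assay, butyl in place of hydrogen on a saturated chain carbon, five bonds along the chain from an oxygen on an aromatic ring, gives an at least 2.5-fold higher number from compound 1 to compound 3 (0.40 log units; beyond the scatter), so a second, longer chain at this place also falls on the high side of compound 1, and this step too is only a lower bound. The step between compound 2 and compound 3 cannot be read, so the extra methyl can be given neither a direction nor a size. Both longer chains stand at the same limit and not at a number, which now caps what the series can show at this place: the limit of > 100 mg/kg in this assay, at which 2 of the 3 values shown sit.

From the compounds shown here alone, how far the two longer chains truly lie beyond that limit remains open, as does any difference between them. Going by these compounds, it is also open whether a shorter chain such as propyl, or an amine at the end of the chain, would give a lower number than compound 1 at 39.4 mg/kg, which would show whether a pentyl chain lies near the low end of this read-out.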